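Oxadiazole aryl swap in the armyworm series

The source may hold more compounds than are shown below. What is called first, only, known or untested is meant among the compounds shown, and "the series" means these compounds.

Measured so far:
compound 1 `Cc1ccc(-c2nnc(COc3cnn(C(C)(C)C)c(=O)c3Cl)o2)cc1`: 19900 nM
compound 2 `CCCCn1ncc(OCc2nnc(-c3ccccc3)o2)c(Cl)c1=O`: > 299000 nM, a limit of the assay
compound 3 `CCCCn1ncc(OCc2nnc(-c3ccc(F)cc3)o2)c(Cl)c1=O`: 161000 nM

In a functional assay on the whole organism for inhibition, with Mythimna separata as the target, with a stated time of 5 days (on this read-out higher numbers stand for an effect only at larger amounts of compound and lower numbers for an effect already at smaller amounts), compound 1 gives 19900 nM, the lowest of the two numbers recorded; compound 3 gives 161000 nM, a step beyond the scatter. For compound 2 only a limit is recorded, (the limit of > 299000 nM in this assay, at which 1 of the 3 values shown sits). Among the compounds with values here, the one measured step, an at least 1.8-fold lower number from compound 2 to compound 3 (0.26 log units; that floor lies within the scatter), is fluoro in place of hydrogen on an aromatic carbon and has a floor within the scatter, so it shows little. Compound 1 and compound 3 differ in two places, so their gap cannot be assigned to the aryl group alone.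

Compound 4 `CC(C)(C)n1ncc(OCc2nnc(-c3cccc(F)c3)o2)c(Cl)c1=O` is not yet measured. It differs from compound 1 by 3-fluorophenyl in place of 4-methylphenyl on an aromatic carbon. Within the data shown here, no measured step covers the loss of the methyl or the shift of the fluorine, so the expectation rests on the weak fluoro step and the spread of the series. In this assay compound 4 is estimated at 40000 nM, between 10000 nM and 160000 nM, which would be an expected step of a 2.0-fold higher number from compound 1 to compound 4 (0.30 log units; within the scatter).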

Compound 4, half-maximal effective concentration: 7100 nM
Estimate against measurement, compound 4: 5.6-fold (0.75 log units) above; measured number below the stated range.
By their numbers in this assay, from the lowest: compound 4; then compound 1; then compound 3. At a limit, above all of these: compound 2.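

In this assay, with the rest of the structure held, 3-fluorophenyl in place of 4-methylphenyl gives a 2.8-fold lower number from compound 1 to compound 4 (0.45 log units; beyond the scatter), so the aryl group on this aromatic carbon of the five-membered ring does affect the read-out. Within the data shown here, the earlier single-place change, an at least 1.8-fold lower number from compound 2 to compound 3 (0.26 log units; that floor lies within the scatter), has a floor within the scatter, which makes this the first step that can be read as a real change. It is modest, however, and the methyl leaves as the fluorine enters, so it covers two changes to the aryl group at once.

Neither phenyl itself, 4-fluorophenyl nor 3-chlorophenyl is shown on the core of compound 1, so the roles of the methyl and the fluorine cannot yet be separated. No measured property shown here offers a cause for the step.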